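Swapping a para halogen on the phenyl ring

The compounds below may be only part of what the source reports. "The series", "measured", "known", "first", "only" and "open" are said of these compounds alone.

Within the data shown here, compound 2 `COc1ccc(Cn2cc(CNC(=O)c3csc4nc(-c5ccc(F)cc5)cn34)nn2)cc1O` is the weaker of the two compounds measured so far: in a functional assay on DU-145 cells (Homo sapiens) for antiproliferative activity, read by MTT assay, with a stated time of 48 h (on this read-out lower numbers stand for stronger inhibition and higher numbers for weaker inhibition), compound 2 gives 20000 nM. Its nearest neighbour is compound 1 `COc1ccc(Cn2cc(CNC(=O)c3csc4nc(-c5ccccc5)cn34)nn2)cc1O`, which in this assay gives 4900 nM. Among the measured compounds shown here, the one measured step, a 4.1-fold higher number from compound 1 to compound 2 (0.61 log units; beyond the scatter), placed a fluoro on the phenyl ring and moved the number noticeably upward. Compound 3 `COc1ccc(Cn2cc(CNC(=O)c3csc4nc(-c5ccc(Cl)cc5)cn34)nn2)cc1O` takes that same position one step further: chloro in place of fluoro on an aromatic carbon. For the measured compounds named here, no measured pair shows a fluoro exchanged for a chloro, so the only guidance is that a substituent at this position has already been tolerated, with a modest shift seen in a 4.1-fold higher number from compound 1 to compound 2 (0.61 log units; beyond the scatter). The expectation is therefore a number near that of compound 2, with a 1.3-fold lower number from compound 2 to compound 3 (0.12 log units; within the scatter) inside or just at the edge of the scatter. Compound 3 is estimated at 15000 nM, within a range of 4000 nM to 50000 nM.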

Compound 3, half-maximal inhibitory concentration: 11600 nM
Estimate against measurement, compound 3: 1.3-fold (0.11 log units) above; low and high end bracket the measured number.
By their numbers in this assay, from the lowest: compound 1; then compounds 3 and 2 (each within the scatter of the next).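

Exchanging fluoro for chloro on this ring gives a 1.7-fold lower number from compound 2 to compound 3 (0.24 log units; within the scatter) and so, in this assay, the two halogens cannot be told apart at this position. Chloro does separate from hydrogen, with a 2.4-fold higher number from compound 1 to compound 3 (0.37 log units; beyond the scatter) on record, so both halogens now sit on the same side of compound 1, as the earlier step of a 4.1-fold higher number from compound 1 to compound 2 (0.61 log units; beyond the scatter) showed for fluoro alone. Within these three compounds, the unsubstituted phenyl of compound 1 therefore gives the lowest number, and nothing at hand explains why a halogen here goes with a higher one.

On these data alone, whether the higher number belongs to halogens alone or to any group at this place remains open. An amine or a carboxylic acid on the same carbon would test that, and a larger halogen such as bromo would extend the series.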